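Methyl on the core of compound 1: oral exposure notes

The source may report more compounds than this note shows. Statements on the series, on what has been measured and on what is new or still open speak of the compounds shown alone.

Measured compounds:
compound 1 `C[C@H](Nc1nc(N)nc(N)c1C#N)c1cc2ccc(F)cn2c(=O)c1-c1ccccc1`, 22%
compound 2 `C[C@H](Nc1nc(N)nc(N)c1C#N)c1cc(=O)n2cc(F)ccc2c1-c1cc(F)cc(F)c1`, 60%

In an ADME assay on the whole organism (Mus musculus, strain BALB/C) for pharmacokinetics, read by LC-MS, with a stated time of 24 h, at a dose of 10 mg/kg by the oral route (on this read-out lower numbers stand for lower oral bioavailability and higher numbers for higher oral bioavailability), compound 1 gives 22%, the lowest of the two numbers on hand. Compound 2 gives 60% in this assay, a number beyond the scatter above that of compound 1; the two differ in more than one place, so this gap cannot be assigned to one change and is read only as the spread of the pair.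

Compound 3 `Cc1c([C@H](C)Nc2nc(N)nc(N)c2C#N)c(-c2ccccc2)c(=O)n2cc(F)ccc12` is the next entry. Compared with compound 1 it carries methyl in place of hydrogen on an aromatic carbon, that is methyl in place of hydrogen on an aromatic carbon of the shared core, at a position ortho to a fused ring and ortho to a large group. Going by the values given here, no pair of measured compounds differing in one place is available, so there is no measured step to lean on for this change.

The expected step from compound 1 to compound 3 is small, a number 6 percentage points higher from compound 1 to compound 3 (within the scatter), with no clear direction and probably within the scatter. For compound 3 the estimate in this assay is 28%, in the range 10% to 50%.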

Compound 3, oral bioavailability: 30%
Compound 3: the middle estimate sits 2 percentage points below what was measured, within the range that was stated.
By their numbers in this assay, from the lowest: compounds 1 and 3 (each within the scatter of the next); then compound 2.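

Going by these compounds alone, compounds 1 and 2 offered no pair differing in one place, so the step of a number 8 percentage points higher from compound 1 to compound 3 (within the scatter) in this assay is the first one-place reading on the shared core. It shows that methyl in place of hydrogen on an aromatic carbon, at this position ortho to a fused ring and ortho to a large group, leaves oral bioavailability in the same band as the parent and gives no change that can be told from the scatter. No measurement is at hand that bears on why the number behaves this way.

As far as these compounds go, whether any other group at this position, such as an amine, a carboxylic acid or a longer chain, would give a step beyond the scatter remains open, as a single small alkyl group says nothing about those. From the compounds shown here alone, compound 2 differs from both compound 1 and compound 3 in more than one place, so its gap stays unassigned, and whether the methyl step would read the same on the aromatic group of compound 2 is also open.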